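The source may hold more compounds than are shown below. What is called first, only, known or untested is meant among the compounds shown, and "the series" means these compounds.

Of the compounds shown here, three sharing one core have been measured in an ADME assay on microsomes from liver (Canis lupus familiaris) for metabolic stability, with a stated time of 10 min; a lower number here means that less of the compound is left, a higher number that more of the compound is left. Compound 1 `Fc1ccccc1-c1ccc2[nH]c(C3=NOC4(CCCCC4)C3)nc2c1` gives 47%, compound 2 `Fc1cccc(C(F)(F)F)c1-c1ccc2[nH]c(C3=NOC4(CCCCC4)C3)nc2c1` gives 65%, and compound 3 `Fc1cc(-c2ccccc2C(F)(F)F)cc2nc(C3=NOC4(CCCCC4)C3)[nH]c12` gives 87%. Compound 3 therefore stands highest of the three, clearly ahead of both others.

The next compound, compound 4 `N#Cc1cc(-c2ccccc2C(F)(F)F)cc2nc(C3=NOC4(CCCCC4)C3)[nH]c12`, keeps all of compound 3 except for one group. The change is cyano in place of fluoro on an aromatic carbon: cyano takes the place of fluoro on an aromatic carbon, ortho to a fused ring and meta to a 2-(trifluoromethyl)phenyl group.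

Among the measured compounds shown here, no measured pair shows this swap. For the measured compounds named here, the only measured step between compounds differing in one place is a number 18 percentage points higher from compound 1 to compound 2 (beyond the scatter), and it concerns trifluoromethyl in place of hydrogen. That step bears on the question only loosely: it shows that one substitution in this series can produce a modest shift, but it gives no direction for replacing fluoro with cyano. With so little evidence, the expectation is for no change beyond the scatter, with a slight lean downward since compound 3 already gives 87% and has little room to rise. The expected result is a number 7 percentage points lower from compound 3 to compound 4 (within the scatter). The estimate for compound 4 is 80%, within an expected range from 60% to 95%.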

Compound 4, percent of the compound remaining: 51%
The estimate for compound 4 lay 29 percentage points above the measured number; the whole stated range lies above it.
By their numbers in this assay, from the lowest: compounds 1 and 4 (each within the scatter of the next); then compound 2; then compound 3.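

Measured in this assay, cyano in place of fluoro gives a number 36 percentage points lower from compound 3 to compound 4 (beyond the scatter), a large step for a change of one small group. This position, ortho to a fused ring and meta to a 2-(trifluoromethyl)phenyl group, is therefore not indifferent to what it carries, at least when the choice is between these two groups. Among the compounds shown here, the earlier step, a number 18 percentage points higher from compound 1 to compound 2 (beyond the scatter), concerned another change and went upward, so the new step adds the first single-group change in this set with a lower number, while nothing available here bears on why the number fell.

From the compounds shown here alone, with only fluoro and cyano compared at this position, it remains open whether the drop belongs to cyano in particular or would come with other replacements of fluoro. A chlorine, a methyl group or an amine on the same aromatic carbon, with the rest of compound 3 kept, would help separate those two readings, and the compounds shown cannot say which of them would keep more of the compound intact.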